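Stereoisomers at the stability limit

This account rests on a few compounds, and the source may have more. Where it says the series, first, only, none or still open, it means among the compounds named here.

Measured in an ADME assay (Mus musculus, strain C57BL/6) for metabolic stability, read by HPLC, with a stated time of 12 h; a lower number here means that the compound disappears faster, a higher number that the compound lasts longer:
compound 1 `O=C(O)[C@@H](CO)NC(=O)[C@H]1C[C@@H](O)CN1` gives > 12 h
compound 2 `O=C(O)[C@@H](CO)NC(=O)[C@H]1C[C@H](O)CN1` gives > 12 h
compound 3 `O=C(N[C@H](CO)C(=O)O)[C@@H]1C[C@H](O)CN1` gives > 12 h

Compound 3 stands at > 12 h, which is a limit and not a number. Next is compound 4 `O=C(O)[C@H](CO)NC(=O)[C@H]1C[C@@H](O)CN1` with this change: the two compounds have the same atoms and bonds and differ only in configuration as drawn: 3 of 3 stereo elements differ (all stereocentres are inverted: mirror images); a stereocentre at a saturated chain carbon is drawn R in compound 3 and S in compound 4; a stereocentre at a saturated ring carbon is drawn S in compound 3 and R in compound 4; a stereocentre at a saturated ring carbon is drawn S in compound 3 and R in compound 4. Going by the values given here, three measured steps bear on it, each a change of configuration only: a step that the two limits leave unreadable from compound 1 to compound 2 and a step that the two limits leave unreadable from compound 1 to compound 3 and a step that the two limits leave unreadable from compound 2 to compound 3. All three compounds sit at the limit of > 12 h in this assay, at which 3 of the 3 values shown sit, so these steps give no size. No step beyond the scatter is expected in this assay and no direction can be assigned. The expected step runs a step that the limit leaves unreadable from compound 3 to compound 4 and will probably be unreadable. Compound 4 is estimated at 14 h with an expected range of 10 h to 24 h and will most likely be reported as a limit again.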

Compound 4, half-life: > 12 h
Compound 4: a limit, no number; the forecaster's own chance of this, stated with the estimate: 90%; the middle value lies beyond the limit too.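

In this assay compound 4 gives > 12 h, which is a limit and not a number. Its steps from compound 1, compound 2 and compound 3 cannot be read. The compounds shown leave open whether configuration alters half-life at all in this assay.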